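Distal Aryl Swap and the Acid Dissociation of Compound 3

The source may hold more compounds than are shown below. What is called first, only, known or untested is meant among the compounds shown, and "the series" means these compounds.

Within the data shown here, compound 2 `COc1ccc(Oc2ccc3c(NCCCNCc4cc(F)ccc4OC)ccnc3c2)cc1` is one of two compounds so far with a number in a physicochemical assay for acid dissociation. In this assay compound 2 gives 9.28, and its only companion, compound 1 `Cc1cc(C)cc(Cc2ccc3c(NCCCNCc4ccco4)ccnc3c2)c1`, gives 9.47; the two lie within the scatter of each other, so compound 2 is not set apart from compound 1 on this measure. Compound 3 `COc1ccc(F)cc1CNCCCNc1ccnc2cc(-c3ccc(F)cc3)ccc12` has not yet been measured in this assay. It differs from compound 2 in one place: 4-fluorophenyl in place of 4-methoxyphenoxy on an aromatic carbon. Among the measured compounds shown here, no step between two measured compounds exists to calibrate a change of this kind, and the change leaves the amine-bearing chain of the shared core untouched. Compound 3 is therefore expected to give 9.3 in this assay, within a range from 9 to 9.6. The implied step a number 0.02 log units higher from compound 2 to compound 3 (within the scatter) is expected to stay within the scatter, with no clear direction.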

Compound 3, acid dissociation constant: 9.47
Beside the measured number, compound 3's estimate is 0.17 log units below it, and the stated range covers the measured number.
By their numbers in this assay, from the lowest: compounds 2, 1 and 3 (each within the scatter of the next).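

In this assay, among these compounds, 4-fluorophenyl in place of 4-methoxyphenoxy gives a number 0.19 log units higher from compound 2 to compound 3 (within the scatter), the first step at this position that can be read, since the earlier compounds offered no pair differing in one place. The step shows that a group counted with hydrogen-bond acceptors can give way to one counted with none on this aromatic carbon, while the read-out still does not separate the two compounds. Nothing measured in the material at hand explains this result.

Going by these compounds, whether an amine or a carboxylic acid on this aromatic carbon would give a step beyond the scatter remains open. On these data alone, it is also open whether a longer chain in that place would do so, or whether the same swap would read alike with the amine-bearing chain changed.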